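Changing the ether ring of compound 3

A few compounds are considered here, and "the series" means these few. Any claim that something is new, unique, unknown or untested is made for them only; others in the source may bear on it.

Measured so far:
- compound 1 `Cc1cc(Oc2ccc(-c3ccn4c(CC5CC5)nnc4c3C(F)(F)F)cc2F)ccn1` gives 9.2 nM
- compound 2 `Clc1cc(-c2ccn3c(CC4CC4)nnc3c2Cl)ccc1OC1CCOCC1` gives 28.1 nM
- compound 3 `FC(F)(F)c1c(-c2ccc(OC3CCOCC3)c(Cl)c2)ccn2c(CC3CC3)nnc12` gives 12.3 nM

These three compounds were tested in an assay on cells for binding affinity to metabotropic glutamate receptor 2 (Homo sapiens), read by scintillation proximity assay; on this read-out higher numbers stand for weaker binding and lower numbers for tighter binding. Compound 3 stands second of the three numbers. Its value and that of compound 1 lie within the usual scatter of each other, so nothing separates them. Compound 2 is further away: the step of a 2.3-fold lower number from compound 2 to compound 3 (0.36 log units; beyond the scatter) is beyond the scatter, and it comes from a trifluoromethyl in place of a chloro on an aromatic carbon.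

Compound 4 `O[C@H]1CC[C@H](Oc2ccc(-c3ccn4c(CC5CC5)nnc4c3C(F)(F)F)cc2Cl)CC1` keeps everything of compound 3 except the ring attached to the aryl oxygen: 4-hydroxycyclohexyl in place of oxan-4-yl on an oxygen on an aromatic ring. For the measured compounds named here, no measured pair differs in this position, so the only known step, from compound 2 to compound 3, concerns a different part of the molecule and says nothing about what an ether ring swap does here. With no guidance from the data, the step of a 1.0-fold lower number from compound 3 to compound 4 (0.01 log units; within the scatter) is expected to stay within the scatter. Compound 4 is therefore estimated at 12 nM, with a range from 4 nM to 40 nM that reflects this uncertainty.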

Compound 4, dissociation constant: 3 nM
Estimate against measurement, compound 4: 4.0-fold (0.60 log units) above; measured number below the stated range.
By their numbers in this assay, from the lowest: compound 4; then compounds 1 and 3 (each within the scatter of the next); then compound 2.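

Swapping oxan-4-yl for 4-hydroxycyclohexyl on an oxygen on an aromatic ring gives a 4.1-fold lower number from compound 3 to compound 4 (0.61 log units; beyond the scatter) in this assay and shows that this ring affects the number. For the compounds shown here, the earlier step, trifluoromethyl in place of chloro, concerned a different part of the molecule, so this is the first measured sign that the position responds to change, with a step beyond the scatter. The change alters more than one feature, since a ring oxygen gives way to carbon, a hydrogen-bond donor enters and two defined stereocentres appear, and nothing measured here links the step to any one of these features.

Going by these compounds, it remains open whether plain cyclohexyl, without the hydroxyl, would give a number closer to that of compound 3 or of compound 4, and whether the other stereoisomer of 4-hydroxycyclohexyl would behave alike. Also unknown is how an amine or a carboxylic acid would fare in place of the hydroxyl, and whether the same ring swap would give a similar step with chloro in place of trifluoromethyl on the shared core.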